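Vero cell cytotoxicity of a trifluoromethoxyphenyl amide

A few compounds are considered here, and "the series" means these few. Any claim that something is new, unique, unknown or untested is made for them only; others in the source may bear on it.

Compound 1 `CCN(CC)c1cc2[nH]c(C3CCCCC3)nc2cc1NC(=O)NCc1ccccc1`: > 100 ug/mL
Compound 2 `Cc1ccc(C(=O)Nc2cc3nc(C4CCCCC4)[nH]c3cc2N2CCCC2)cc1`: > 100 ug/mL
Compound 3 `O=C(NCc1ccccc1)Nc1cc2nc(C3CCCCC3)[nH]c2cc1N1CCCC1`: > 100 ug/mL

In an ADME assay on Vero cells (Chlorocebus sabaeus) for cytotoxicity, read by resazurin assay, with a stated time of 3 days (a lower number here means a stronger inhibitor, a higher number a weaker inhibitor), compound 1 gives > 100 ug/mL, which is a limit of the assay rather than a number. Compound 2 also reports a limit, > 100 ug/mL. Compound 3 likewise reports a limit, > 100 ug/mL. Compound 4 `CCN(CC)c1cc2[nH]c(C3CCCCC3)nc2cc1NC(=O)c1ccc(OC(F)(F)F)cc1` differs from compound 1 in one place: 4-(trifluoromethoxy)phenyl in place of benzylamino on a carbonyl carbon. The two measured steps that could guide an expectation, a step that the two limits leave unreadable from compound 1 to compound 3 and a step that the two limits leave unreadable from compound 2 to compound 3, cannot be sized because of the limit of > 100 ug/mL in this assay, at which 3 of the 3 values shown sit. With no readable step at hand, no change beyond the usual scatter is expected from this replacement. Compound 4 is therefore estimated at 100 ug/mL, within a range from 50 ug/mL to 200 ug/mL, which means an expected step of a number no higher from compound 1 to compound 4 (the limit leaves the size open).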

Compound 4, half-maximal inhibitory concentration: > 100 ug/mL
Compound 4 ended at the assay's limit; the forecaster's own chance of this, stated with the estimate: 75%; the middle value sits exactly at the limit.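

Compound 1 and compound 4 both sit at a limit of this assay, so no step between them can be read: the limit of > 100 ug/mL in this assay, at which 4 of the 4 values shown sit.

As far as these compounds go, the concentration at which any of compound 1, compound 2, compound 3 or compound 4 would harm these cells remains open, as does any difference among them.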